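Lengthening a side chain and rat oral exposure

The source may report more compounds than this note shows. Statements on the series, on what has been measured and on what is new or still open speak of the compounds shown alone.

Measured so far in an ADME assay on the whole organism (plasma) for pharmacokinetics, with Rattus norvegicus as the target, with a stated time of 24 h, at a dose of 10 mg/kg by the oral route; on this read-out higher numbers stand for higher exposure at the dose given and lower numbers for lower exposure:
Compound 1 `CCCC[C@H](NC(=O)[C@@H]1[C@H]2[C@@H](CN1C(=O)[C@@H](NC(=O)NC1([C@H]3CCCS3(=O)=O)CCCCC1)C1(C)CCCCC1)C2(C)C)C(=O)C(=O)NC1CC1` gives 1980 ng.h/mL
Compound 2 `CCC[C@H](NC(=O)[C@@H]1[C@H]2[C@@H](CN1C(=O)[C@@H](NC(=O)NC1([C@H]3CCCS3(=O)=O)CCCCC1)C1(C)CCCCC1)C2(C)C)C(=O)C(=O)NC1CC1` gives 862 ng.h/mL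

Going by the values given here, compound 2 holds the lower of the two numbers, at 862 ng.h/mL in this assay so far. The change to compound 3 `CC1([C@H](NC(=O)NC2([C@H]3CCCS3(=O)=O)CCCCC2)C(=O)N2C[C@@H]3[C@H]([C@H]2C(=O)N[C@@H](CCC2CC2)C(=O)C(=O)NC2CC2)C3(C)C)CCCCC1` is cyclopropyl in place of methyl on a saturated chain carbon, three bonds along the chain from an amide-type nitrogen and a carbonyl carbon and it amounts to cyclopropyl in place of methyl on a saturated chain carbon, three bonds along the chain from an amide-type nitrogen and a carbonyl carbon. Cut one bond further out, this reads propyl to 2-cyclopropylethyl. Among the compounds with values here, the one measured step bearing on this is a 2.3-fold lower number from compound 1 to compound 2 (0.36 log units; beyond the scatter) and it leaves the shorter chain, in compound 2, with the lower number. Compound 3 also adds carbon to that chain, but as a ring, which neither measured compound carries, so this step is only a rough guide. The expected step is a 1.9-fold higher number from compound 2 to compound 3 (0.27 log units; within the scatter) in the upward direction, modest and uncertain. Compound 3 is estimated at 1600 ng.h/mL in a range of 600 ng.h/mL to 4000 ng.h/mL on this evidence.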

Compound 3, area under the concentration-time curve: 1120 ng.h/mL
The estimate for compound 3 lay 1.4-fold (0.15 log units) above the measured number, within the range that was stated.
By their numbers in this assay, from the lowest: compounds 2, 3 and 1 (each within the scatter of the next, the first and the last beyond it).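

In this assay, the cyclopropyl in place of methyl gives a 1.3-fold higher number from compound 2 to compound 3 (0.11 log units; within the scatter) and, set against the chain of compound 1, the cyclopropyl in place of ethyl gives a 1.8-fold lower number from compound 1 to compound 3 (0.25 log units; within the scatter) and so compound 3 cannot be told apart from either of the others, although compound 1 and compound 2 do stand apart from each other. This is what the two chains without a ring could not show: a chain ending in a ring at this position does not separate from either of them on this read-out. No measurement at hand explains these numbers.

The compounds shown leave open how a longer straight chain than that of compound 1, or a chain ending in an amine or a carboxylic acid, would read at this position. They also leave open whether a cyclobutyl ring in place of the cyclopropyl would read any differently.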